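Swapping hydroxy for 2-aminophenyl on the amide-type nitrogen

The source may hold more compounds than are shown below. What is called first, only, known or untested is meant among the compounds shown, and "the series" means these compounds.

In a functional assay on NCI-H661 cells (Homo sapiens) for antiproliferative activity, with a stated time of 48 h (a lower number here means a stronger inhibitor, a higher number a weaker inhibitor), compound 1 `CC1(CCCCC(=O)NO)Cc2ccccc2C1=O` gives > 25000 nM, which is a limit and not a number. Compound 2 `CC1(CCCCCCC(=O)NO)Cc2ccccc2C1=O`, which carries a longer chain, gives 20000 nM in this assay. Going by the values given here, the only measured step is an at least 1.2-fold lower number from compound 1 to compound 2 (0.09 log units; that floor lies within the scatter). It changes the chain and leaves the end group untouched, so it gives no direct size for a change at that end group.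

Compound 3 `CC1(CCCCC(=O)Nc2ccccc2N)Cc2ccccc2C1=O` keeps the chain and core of compound 1 and differs from it as follows: 2-aminophenyl in place of hydroxy on an amide-type nitrogen. Among the compounds with values here, no measured step covers this swap. On the small chain step an at least 1.2-fold lower number from compound 1 to compound 2 (0.09 log units; that floor lies within the scatter), no shift beyond the scatter is expected in this assay, in either direction. Compound 3 is estimated at 20000 nM, with an expected range of 7000 nM to 60000 nM. The expected step is an at least 1.2-fold lower number from compound 1 to compound 3 (0.09 log units; that floor lies within the scatter).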

Compound 3, half-maximal inhibitory concentration: > 25000 nM
Compound 3 was reported as a limit; the forecaster's own chance of this, stated with the estimate: 45%; at least 1.2-fold (0.09 log units) between middle value and limit.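

The swap from compound 1 to compound 3 gives no readable step in this assay, because both values are limits: the limit of > 25000 nM in this assay, at which 2 of the 3 values shown sit.

The compounds shown leave open whether 2-aminophenyl in place of hydroxy on an amide-type nitrogen shifts the number in this assay at all, and in which direction.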